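A few compounds are considered here, and "the series" means these few. Any claim that something is new, unique, unknown or untested is made for them only; others in the source may bear on it.

In a functional assay on HT-29 cells (Homo sapiens) for antiproliferative activity, read by sulforhodamine B assay, with a stated time of 48 h (on this read-out lower numbers stand for stronger inhibition and higher numbers for weaker inhibition), compound 1 `CC(C)(C)c1ccc(NS(=O)(=O)c2ccc(N3CCNC3=O)cc2)cc1` gives > 1000 nM, which is a limit of the assay. Compound 2 `O=C1NCCN1c1ccc(S(=O)(=O)Nc2ccc(OC(F)F)cc2)cc1` gives 650 nM, and compound 3 `O=C1NCCN1c1ccc(S(=O)(=O)Nc2ccc(Br)cc2)cc1` gives 300 nM, the lowest number in the set. Compound 4 `COc1ccc(NS(=O)(=O)c2ccc(N3CCNC3=O)cc2)cc1` carries methoxy in place of bromo on an aromatic carbon. Two measured steps at this place bear on it, both toward bromo: a 2.2-fold lower number from compound 2 to compound 3 (0.34 log units; beyond the scatter) and an at least 3.3-fold lower number from compound 1 to compound 3 (0.52 log units; beyond the scatter). Methoxy has not been tested here, but the closest group measured is the difluoromethoxy of compound 2, so a modest rise in the number is expected, similar in size to a 2.2-fold lower number from compound 2 to compound 3 (0.34 log units; beyond the scatter). The expected step is a 1.8-fold higher number from compound 3 to compound 4 (0.26 log units; within the scatter). For compound 4 the estimated value is 550 nM, with an expected range of 220 nM to 1300 nM.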

Compound 4, half-maximal inhibitory concentration: 800 nM
Compound 4: middle estimate off by 1.5-fold (0.16 log units), on the low side, and the stated range covers the measured number.
By their numbers in this assay, from the lowest: compound 3; then compounds 2 and 4 (each within the scatter of the next). At a limit, above all of these: compound 1.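

In this assay the change from bromo to methoxy costs activity (a 2.7-fold higher number from compound 3 to compound 4 (0.43 log units; beyond the scatter)), so bromo now stands clear of both oxygen-linked groups at this position. Methyl and difluoromethyl on that oxygen cannot be told apart (a 1.2-fold higher number from compound 2 to compound 4 (0.09 log units; within the scatter)). Methoxy also cannot be separated from tert-butyl (an at least 1.2-fold lower number from compound 1 to compound 4 (0.09 log units; that floor lies within the scatter)), and compound 1 is held at a limit: the limit of > 1000 nM in this assay, at which 1 of the 4 values shown sits.

As far as these compounds go, whether chloro or iodo would match bromo remains open. So does the effect of an amine or a nitrile at this position.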